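The source may report more compounds than this note shows. Statements on the series, on what has been measured and on what is new or still open speak of the compounds shown alone.

Measured compounds in the series:
compound 1 `O=C(O)c1ccc(/C=C2\SC(=S)N(c3ccccc3)C2=O)cc1` gives only a limit in an assay on isolated protein for inhibition of Apoptosis regulator Bcl-2 (Homo sapiens), read by fluorescence polarization (on this read-out lower numbers stand for stronger inhibition and higher numbers for weaker inhibition), > 10000 nM.
compound 2 `O=C(O)c1ccc(COc2cccc(/C=C3\SC(=S)N(c4ccc([N+](=O)[O-])cc4)C3=O)c2)cc1` gives only a limit in this assay, > 10000 nM.
compound 3 `COc1ccc(N2C(=O)/C(=C/c3ccc(OCc4ccc(C(=O)O)cc4)cc3)SC2=S)cc1` gives only a limit in this assay, > 10000 nM.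

Compound 3 therefore stands at the limit of the assay, with no number of its own; every value shown so far sits at the same limit (the limit of > 10000 nM in this assay, at which 3 of the 3 values shown sit), so nothing separates the three. The step to compound 4 `O=C(O)c1ccc(COc2ccc(/C=C3\SC(=S)N(Cc4ccc(F)cc4)C3=O)cc2)cc1` is 4-fluorobenzyl in place of 4-methoxyphenyl on an amide-type nitrogen in a ring, two ring bonds from the ring sulfur. For the measured compounds named here, no measured step exists, so the expectation can rest only on the shared core and the limit at which compounds 1 to 3 all sit. The expected step from compound 3 to compound 4 in this assay is a number no higher from compound 3 to compound 4 (the limit leaves the size open), none beyond the scatter. Compound 4 is estimated at 10000 nM, within 3000 nM to 30000 nM, most likely again reported only as a limit.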

Compound 4, inhibition constant: > 10000 nM
Compound 4 gave a limit, no number; the forecaster's own chance of this, stated with the estimate: 80%; the middle value lies on the limit itself.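

No step can be read from compound 3 to compound 4, as both give only a limit: the limit of > 10000 nM in this assay, at which 4 of the 4 values shown sit.

The compounds shown leave open which change on the shared core, if any, would give a number in this assay.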